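This account rests on a few compounds, and the source may have more. Where it says the series, first, only, none or still open, it means among the compounds named here.

Measured compounds:
compound 1 `COc1ccc(SCc2ccc(C(=O)Nc3ccccc3N)cc2)cc1` gives 80.1%
compound 2 `CCc1ccc(SCc2ccc(C(=O)Nc3ccccc3N)cc2)cc1` gives 82.9%
compound 3 `Cc1ccc(SCc2ccc(C(=O)Nc3ccccc3N)cc2)cc1` gives 82.7%

In a functional assay on SMMC-7721 cells (Homo sapiens) for inhibition, read by CCK-8 assay, with a stated time of 72 h, tested at 8 uM (a higher number here means more inhibition of growth at the concentration tested, a lower number less inhibition of growth), compound 3 gives 82.7% and stands level with the other two. Its gaps to them are a number 0.2 percentage points lower from compound 2 to compound 3 (within the scatter) and a number 2.6 percentage points higher from compound 1 to compound 3 (within the scatter), so no order can be read among the three.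

Compound 4 `Nc1ccccc1NC(=O)c1ccc(CSCCc2ccccc2)cc1` replaces the whole group on the sulfur: phenethyl in place of 4-methylphenyl on a sulfur. In words, this is phenethyl in place of 4-methylphenyl on a sulfur.

Among the compounds with values here, no measured step makes this kind of change. The closest evidence is a number 2.8 percentage points higher from compound 1 to compound 2 (within the scatter), together with the two gaps above, and these steps only swap methoxy, ethyl and methyl on an aromatic carbon. They offer a weak guide at best, so the range must stay wide. In this assay a small fall is expected, probably not beyond the scatter. The expected change is a number 7.7 percentage points lower from compound 3 to compound 4 (within the scatter). For compound 4 the estimated value is 75%, with an expected range from 55% to 90%.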

Compound 4, percent growth inhibition at one concentration: 77.9%
The estimate for compound 4 lay 2.9 percentage points below the measured number; the range from low to high includes it.
By their numbers in this assay, from the lowest: compounds 4, 1, 3 and 2 (each within the scatter of the next).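

The earlier compounds shown here changed only a small group on the aromatic ring, whereas compound 4 replaces the entire group on the sulfur. Even so, in this assay all three new steps stay within the scatter: a number 4.8 percentage points lower from compound 3 to compound 4 (within the scatter) and a number 5 percentage points lower from compound 2 to compound 4 (within the scatter) and a number 2.2 percentage points lower from compound 1 to compound 4 (within the scatter). At this one concentration, then, the sulfur can carry phenethyl in place of a substituted phenyl group without a readable change in growth inhibition, and nothing available explains this result.

Still open, on these data alone, is whether the aromatic ring of phenethyl matters at all, which a plain hexyl chain on the sulfur would help to test, and whether an amine or a carboxylic acid on that ring would keep the number level. Also open, as far as these compounds go, is whether these four compounds would stay level at lower concentrations, where differences hidden at this single test concentration could appear.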